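Moving the fluorine on the benzyl group of compound 1

A few compounds are considered here, and "the series" means these few. Any claim that something is new, unique, unknown or untested is made for them only; others in the source may bear on it.

Compound 1 `Cc1cc(Nc2nc(NCc3ccc(F)cc3)nc3ccccc23)n[nH]1` is the reference point of this small set. In an assay for inhibition of high affinity nerve growth factor receptor (Homo sapiens), read by HTRF, with a stated time of 30 min, in the presence of a further agent that is not named here (on this read-out higher numbers stand for weaker inhibition and lower numbers for stronger inhibition), compound 1 gives 20 nM, the lowest of the three numbers measured. Compound 2 `Cc1cc(Nc2nc(NCc3ccc(C#N)cc3)nc3ccccc23)n[nH]1` gives 83 nM in this assay, and compound 3 `Cc1ccc(CNc2nc(Nc3cc(C)[nH]n3)c3ccccc3n2)cc1` gives 110 nM. Both changes away from compound 1 weaken inhibition: a 4.2-fold higher number from compound 1 to compound 2 (0.62 log units; beyond the scatter) and a 5.5-fold higher number from compound 1 to compound 3 (0.74 log units; beyond the scatter). Between compound 2 and compound 3 the step is a 1.3-fold higher number from compound 2 to compound 3 (0.12 log units; within the scatter).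

Compound 4 `Cc1cc(Nc2nc(NCc3ccccc3F)nc3ccccc23)n[nH]1` keeps every atom of compound 1 but joins them differently: 2-fluorophenyl in place of 4-fluorophenyl on a saturated chain carbon bound to a nitrogen on an aromatic ring. Among the compounds with values here, none of the measured steps moves the fluorine to another position; the two steps from compound 1 replace the fluorine with another group at the same place, so they bear on compound 4 only indirectly. What they show is that any alteration of the 4-fluorophenyl tried so far costs potency by a modest amount in this assay, and the shift to 2-fluorophenyl is expected to behave in the same direction, though the size is uncertain. The expected step from compound 1 to compound 4 in this assay is a 2.3-fold higher number from compound 1 to compound 4 (0.35 log units; beyond the scatter). Compound 4 is therefore estimated at 45 nM, with a range from 15 nM to 140 nM.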

Compound 4, half-maximal inhibitory concentration: 110 nM
Compound 4: middle estimate off by 2.4-fold (0.39 log units), on the low side; the measured number falls inside the stated range.
By their numbers in this assay, from the lowest: compound 1; then compounds 2, 3 and 4 (each within the scatter of the next).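

Moving the fluorine, with no atom gained or lost, is enough to weaken inhibition in this assay: 2-fluorophenyl in place of 4-fluorophenyl gives a 5.5-fold higher number from compound 1 to compound 4 (0.74 log units; beyond the scatter), so at this position the place of the fluorine on the ring matters, and keeping the fluorine does not by itself keep the number of compound 1. The move costs as much as replacing the fluorine with methyl, and no change at the digits printed from compound 3 to compound 4 (within the scatter), while a 1.3-fold higher number from compound 2 to compound 4 (0.12 log units; within the scatter), so compounds 2, 3 and 4 cannot be ranked against one another and compound 1 alone stands apart from them. Nothing available here accounts for the loss on moving the fluorine.

Still open, going by these compounds, is whether any group on the benzyl ring can improve on the 4-fluorophenyl of compound 1, for example a chlorine or a methoxy group in place of the fluorine, or a second fluorine added to the ring. Also open, on these data alone, is how a longer chain carrying the 4-fluorophenyl, or an amine or carboxylic acid on that ring, would read in this assay.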